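The source may report more compounds than this note shows. Statements on the series, on what has been measured and on what is new or still open speak of the compounds shown alone.

Compound 1 `CCCNC(=O)/N=C(\N)NCCCc1sc(N)nc1C` and compound 2 `Cc1nc(N)sc1CCCN/C(N)=N/C(=O)NCC(C)C1CCCCC1` share a core that carries an aminothiazole and an acylguanidine, and both have been measured in a functional assay on membranes from Sf9 cells for agonist activity at histamine H2 receptor (Homo sapiens), read by scintillation counting and GTPgammaS binding, with a stated time of 90 min; on this read-out lower numbers stand for smaller maximal responses and higher numbers for larger maximal responses. Compound 1 gives 0.79, and compound 2 gives 0.65, which is the lower of the two numbers; the step from one to the other, a number 0.14 lower from compound 1 to compound 2 (beyond the scatter), is a modest fall that lies beyond the scatter. Compound 3 `Cc1nc(N)sc1CCCN/C(N)=N/C(=O)NCc1ccccc1` is not yet measured. It differs from compound 2 in one place: phenyl in place of 1-cyclohexylethyl on a saturated chain carbon bound to an amide-type nitrogen. Among the compounds with values here, only one measured step is available, and it concerns a change at a different place, a saturated chain carbon bound to two saturated chain carbons, so it bears on the present change only loosely. That step did show that adding a cyclohexyl ring cost a modest amount of the maximal response. Since compound 3 loses the cyclohexyl-bearing group while gaining a phenyl, a small rise back toward the value of compound 1 is expected rather than a further fall. Compound 3 is therefore estimated to reach 0.72 in this assay, with a plausible range from 0.58 to 0.86, corresponding to an expected step a number 0.070 higher from compound 2 to compound 3 (within the scatter).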

Compound 3, intrinsic activity: the largest response reached, as a fraction of the reference agonist's: 0.91
Compound 3: the middle estimate sits 0.19 below what was measured, and the stated range ends below it.
By their numbers in this assay, from the lowest: compound 2; then compound 1; then compound 3.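

At the saturated chain carbon bound to an amide-type nitrogen, this assay shows that the group carried there matters: phenyl in place of 1-cyclohexylethyl gives a number 0.26 higher from compound 2 to compound 3 (beyond the scatter). The rise does not merely return the maximal response to the level of compound 1, since phenyl in place of ethyl gives a number 0.12 higher from compound 1 to compound 3 (beyond the scatter), which makes compound 3 the highest of the three and places phenyl above both saturated groups seen at this position. No measurement shown here accounts for this order.

The change from compound 2 to compound 3 alters the ring type and the chain linking it at the same time, so these compounds cannot say which of the two matters; a cyclohexyl group attached directly at this carbon would separate them. They also leave open whether the high response is particular to an unsubstituted phenyl or also holds for a pyridyl ring or a methoxyphenyl group in the same place.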